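Nitro to chloro on the benzyl group: series notes

A few compounds are considered here, and "the series" means these few. Any claim that something is new, unique, unknown or untested is made for them only; others in the source may bear on it.

compound 1 `CSCC[C@H](NC(=O)c1ccc(NCc2cncn2Cc2ccc(C#N)cc2)cc1-c1ccccc1)C(=O)O` — limit only: > 10 uM
compound 2 `CSCC[C@H](NC(=O)c1ccc(NCc2cncn2Cc2ccc([N+](=O)[O-])cc2)cc1-c1ccccc1)C(=O)O` — limit only: > 10 uM

In a functional assay on NIH3T3 cells (Mus musculus) (a lower number here means that less compound is needed, a higher number that more compound is needed for the effect), compound 1 gives only the limit > 10 uM. Compound 2 likewise gives only a limit, > 10 uM. The step from compound 1 to compound 2, a step that the two limits leave unreadable from compound 1 to compound 2, therefore has no readable size, as the limit of > 10 uM in this assay, at which 2 of the 2 values shown sit, shows. Compound 2 thus stands at the limit, without a number.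

Compound 3 `CSCC[C@H](NC(=O)c1ccc(NCc2cncn2Cc2ccc(Cl)cc2)cc1-c1ccccc1)C(=O)O` differs from compound 2 by chloro in place of nitro on an aromatic carbon. Among the compounds with values here, the single measured step, nitro for cyano at the same position, bears on this change but gives no size. Compound 3 is expected to stay near the limit, estimated at 20 uM with range 5 uM to 100 uM, implying a step that the limit leaves unreadable from compound 2 to compound 3.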

Compound 3, concentration for half-maximal effect: > 10 uM
Compound 3 was reported as a limit; the forecaster's own chance of this, stated with the estimate: 80%; the middle value is on the limit's open side.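

In this assay compound 3 gives only a limit, > 10 uM, so no step to it from compound 1 or compound 2 can be read: the limit of > 10 uM in this assay, at which 3 of the 3 values shown sit.

The compounds shown leave open whether cyano, nitro and chloro differ at all in this assay.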